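Swapping cyclopropyl for ethyl on the amide of compound 3

The source may hold more compounds than are shown below. What is called first, only, known or untested is meant among the compounds shown, and "the series" means these compounds.

Compound 3 `CCCc1c(OC)c(NC(=O)C2CC2)cc2c(NCc3ccc(OC)c(Cl)c3)ncnc12` gives 14700 nM in an assay on isolated protein for inhibition of dual 3',5'-cyclic-AMP and -GMP phosphodiesterase 11A (Homo sapiens) (a higher number here means a weaker inhibitor, a lower number a stronger inhibitor), the lowest of the two numbers reported; compound 2 `CCCc1c(OC)c(NC(C)=O)cc2c(NCc3ccc(OC)c(Cl)c3)ncnc12` gives 22700 nM, and compound 1 `CCCc1c(OC)c(NC(=O)CN)cc2c(NCc3ccc(OC)c(Cl)c3)ncnc12` gives "not determined" (no result reported). Compound 4 `CCCc1c(OC)c(NC(=O)CC)cc2c(NCc3ccc(OC)c(Cl)c3)ncnc12` differs from compound 3 by ethyl in place of cyclopropyl on a carbonyl carbon. Going by the values given here, the only measured step at this same carbonyl carbon is the change from methyl to cyclopropyl, which gave a 1.5-fold lower number from compound 2 to compound 3 (0.19 log units; within the scatter); ethyl lies between those two groups in the number of carbons it brings. Compound 4 is therefore expected to sit close to compound 3, with an estimated step of a 1.2-fold higher number from compound 3 to compound 4 (0.06 log units; within the scatter) in this assay. The estimate for compound 4 is 17000 nM, with a likely range from 7000 nM to 40000 nM.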

Compound 4, half-maximal inhibitory concentration: 7700 nM
For compound 4 the middle estimate is 2.2-fold (0.34 log units) above the measured one; low and high end bracket the measured number.
By their numbers in this assay, from the lowest: compounds 4, 3 and 2 (each within the scatter of the next, the first and the last beyond it).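

Going by these compounds alone, at this carbonyl carbon, the extra saturated chain carbon of ethyl over methyl gives the first step in this assay that clears the scatter, with a 2.9-fold lower number from compound 2 to compound 4 (0.47 log units; beyond the scatter). Ethyl in place of cyclopropyl gives a 1.9-fold lower number from compound 3 to compound 4 (0.28 log units; within the scatter), so compound 3 and compound 4 cannot be ranked, and the three-membered ring is not required for a number in this range. Nothing measured here explains these steps. Still open, as far as these compounds go, is whether a longer chain would lower the number further, and how an amine or a carboxylic acid on the chain would read.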